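The source may report more compounds than this note shows. Statements on the series, on what has been measured and on what is new or still open speak of the compounds shown alone.

Measured so far in a functional assay on MGC-803 cells (Homo sapiens) for cytotoxicity, read by MTT assay, with a stated time of 72 h; on this read-out higher numbers stand for weaker inhibition and lower numbers for stronger inhibition:
- compound 1 `O=C1C(=Cc2ccc(Br)cc2)C(=O)N(c2ccc(Cl)cc2)N1c1ccc(Cl)cc1` gives 16900 nM
- compound 2 `O=C1C(=C/C=C/c2ccccc2)C(=O)N(c2ccc(Cl)cc2)N1c1ccc(Cl)cc1` gives 5100 nM

Compound 2 holds the lower of these two numbers, and the gap is beyond the scatter. The next compound is compound 3 `O=C1C(=Cc2ccccc2)C(=O)N(c2ccc(Cl)cc2)N1c1ccc(Cl)cc1`, with phenyl in place of 2-phenylethenyl on a double-bonded chain carbon bound to a double-bonded ring carbon.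

Among the measured compounds shown here, one measured step bears on this place: a 3.3-fold lower number from compound 1 to compound 2 (0.52 log units; beyond the scatter), a modest change in which 2-phenylethenyl replaced 4-bromophenyl. Like compound 1, compound 3 lacks 2-phenylethenyl, so a modest rise in the number is expected in this assay, similar in size to that step but opposite in direction. For the measured compounds named here, the step is only a partial guide, since compound 3 also lacks the bromine of compound 1, and no measured pair isolates that difference. The expected change is a 2.7-fold higher number from compound 2 to compound 3 (0.44 log units; beyond the scatter) by this estimate. Compound 3 is estimated at 14000 nM in this assay, with an expected range from 6000 nM to 35000 nM as the working span.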

Compound 3, half-maximal inhibitory concentration: 27200 nM
Compound 3: middle estimate off by 1.9-fold (0.29 log units), on the low side; low and high end bracket the measured number.
By their numbers in this assay, from the lowest: compound 2; then compounds 1 and 3 (each within the scatter of the next).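

In this assay, among the compounds shown here, phenyl in place of 2-phenylethenyl on a double-bonded chain carbon bound to a double-bonded ring carbon gives a 5.3-fold higher number from compound 2 to compound 3 (0.73 log units; beyond the scatter), the first reading of this change with nothing else altered, whereas the earlier step from compound 1 also involved the bromine. Hydrogen in place of bromo on an aromatic carbon gives a 1.6-fold higher number from compound 1 to compound 3 (0.21 log units; within the scatter), so bromo and hydrogen cannot be told apart in this assay, and in this small set the 2-phenylethenyl group of compound 2 alone sets its number apart from those of compound 1 and compound 3. No measurement is available to explain either step.

On these data alone, the benefit of 2-phenylethenyl rests on a single matched pair, so it remains open whether a longer chain with a further double bond would lower the number again, or whether a saturated two-carbon chain would keep the effect of 2-phenylethenyl. Also open, as far as these compounds go, is how an amine or a carboxylic acid on the terminal phenyl would read, and whether bromo on the phenyl of 2-phenylethenyl would stay as silent as it does in compound 1.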